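Shortening a Side Chain in a Cytotoxicity Series

A few compounds are considered here, and "the series" means these few. Any claim that something is new, unique, unknown or untested is made for them only; others in the source may bear on it.

Of the compounds shown here, three have been tested: compound 1 `CCCCCCCCCCn1cc(-c2nc3ccccc3cc2CCC)nn1`, compound 2 `CCCCCc1cc2ccccc2nc1-c1cn(CCC(F)(F)C(F)(F)C(F)(F)C(F)(F)C(F)(F)C(F)(F)C(F)(F)C(F)(F)F)nn1` and compound 3 `CCc1cc2ccccc2nc1-c1cn(-c2ccc(F)cc2)nn1`. In a functional assay on THP-1 cells (Homo sapiens) for cytotoxicity, read by MTT assay, with a stated time of 24 h (a higher number here means a weaker inhibitor, a lower number a stronger inhibitor), compound 1 reaches only the assay limit, > 100 ug/mL. Compound 2 likewise sits at a limit in this assay, giving > 100 ug/mL. Compound 3 also stops at a limit in this assay, with > 100 ug/mL. Compound 2 therefore stands exactly where every measured value stands, because of the limit of > 100 ug/mL in this assay, at which 3 of the 3 values shown sit. Compound 4 `CCCCc1cc2ccccc2nc1-c1cn(CCC(F)(F)C(F)(F)C(F)(F)C(F)(F)C(F)(F)C(F)(F)C(F)(F)C(F)(F)F)nn1` has not yet been measured; it differs from compound 2 by hydrogen in place of methyl on a saturated chain carbon, four bonds along the chain from an aromatic carbon. Going by the values given here, no measured pair shows the effect of such a change, so no shift beyond the scatter is expected in this assay, and the step that the limit leaves unreadable from compound 2 to compound 4 is expected to remain at a limit. Compound 4 is thus estimated at 150 ug/mL, within 80 ug/mL to 400 ug/mL.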

Compound 4, half-maximal inhibitory concentration: > 100 ug/mL
Compound 4 was reported as a limit (the forecaster's own chance of this, stated with the estimate: 85%); the middle value lies beyond the limit too.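

Going by these compounds alone, compound 2 and compound 4 both stop at a limit, so no step between them can be read: the limit of > 100 ug/mL in this assay, at which 4 of the 4 values shown sit. The compounds shown leave open whether this change from methyl to hydrogen alters cytotoxicity at all.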